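This account rests on a few compounds, and the source may have more. Where it says the series, first, only, none or still open, it means among the compounds named here.

Working notes on the hydrazone series. Compound 1 `Cc1ccc(/C=N/NC(=O)CSc2nnnn2C)cc1`, compound 2 `COc1ccc(/C=N/NC(=O)CSc2nnnn2C)cc1` and compound 3 `COc1ccccc1/C=N/NC(=O)CSc1nnnn1C` share a core and differ only in the group on the six-membered aromatic ring of carbon only and its position. In a functional assay on A549 cells (Homo sapiens) for cytotoxicity, read by XTT assay, with a stated time of 24 h (on this read-out lower numbers stand for stronger inhibition and higher numbers for weaker inhibition), compound 1 gives 3160000 nM. Compound 2 reaches only the limit of > 10000000 nM in this assay, which is a limit and not a number (the limit of > 10000000 nM in this assay, at which 1 of the 3 values shown sits). Compound 3 gives 7000000 nM in this assay. The change methyl in place of methoxy on an aromatic carbon brings an at least 3.1-fold lower number from compound 2 to compound 1 (0.50 log units; beyond the scatter). Compound 3 and compound 2 hold the same atoms joined differently; the difference between the two cores is not broken down here.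

Compound 4 `Cc1ccccc1/C=N/NC(=O)CSc1nnnn1C` is not yet measured. It arises from compound 3 by methyl in place of methoxy on an aromatic carbon, the same kind of change as from compound 2 to compound 1, though there the methyl sits para to a large group and here ortho to a large group, so it is not the same change. The expected step of a 2.8-fold lower number from compound 3 to compound 4 (0.45 log units; beyond the scatter) rests on compound 1 and compound 2 through an at least 3.1-fold lower number from compound 2 to compound 1 (0.50 log units; beyond the scatter), read with caution because of the limit (the limit of > 10000000 nM in this assay, at which 1 of the 3 values shown sits). Compound 4 is estimated at 2500000 nM, expected between 1000000 nM and 7000000 nM.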

Compound 4, half-maximal inhibitory concentration: > 10000000 nM
Compound 4: no number, only a limit; the forecaster's own chance of this, stated with the estimate: 10%; middle value at least 4.0-fold (0.60 log units) from the limit.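

In this assay, methyl in place of methoxy on an aromatic carbon brings an at least 1.4-fold higher number from compound 3 to compound 4 (0.15 log units; that floor lies within the scatter), so with the methyl ortho to a large group the change does not repeat the earlier step: the same change on two cores in this assay, an at least 3.1-fold lower number (0.50 log units; beyond the scatter) from compound 2 to compound 1 and an at least 1.4-fold higher number (0.15 log units; that floor lies within the scatter) from compound 3 to compound 4, at least 4.5-fold (0.65 log units) apart, beyond the scatter of two such steps. This shows that the change cannot be carried as one fixed step between these two pairs, but two pairs support no rule for the wider series. As far as these compounds go, compound 2 and compound 4 each stand at a limit and not at a number, so both steps are bounds, and their true sizes and the true gap between them remain unknown: the limit of > 10000000 nM in this assay, at which 2 of the 4 values shown sit.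

From the compounds shown here alone, whether the gap follows from the place of the group on the ring alone stays open, with only two places covered. Also open, going by these compounds, is whether another group in these places, such as an amine or a carboxylic acid, would give a number clear of the limit.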